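Carbamoyl to Acetyl on the Lowest-Reading Compound

A few compounds are considered here, and "the series" means these few. Any claim that something is new, unique, unknown or untested is made for them only; others in the source may bear on it.

Within the data shown here, in a functional assay on HepG2 cells (Homo sapiens) for cytotoxicity, read by MTT assay, with a stated time of 72 h (on this read-out higher numbers stand for weaker inhibition and lower numbers for stronger inhibition), compound 1 `COc1ccc2ccc(=O)oc2c1C1=NN(C(N)=O)C(c2ccc(SC)cc2)C1` gives 18 nM, the lowest of the three numbers measured so far. Compound 3 `COc1ccc2ccc(=O)oc2c1C(/C=C/c1cccs1)=N/NC(N)=O` gives 75 nM and compound 2 `COc1ccc2ccc(=O)oc2c1C1=NN(C(N)=O)C(c2ccc(C(F)(F)F)cc2)C1` gives 96 nM, and both gaps to compound 1 lie beyond the scatter.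

Compound 4 `COc1ccc2ccc(=O)oc2c1C1=NN(C(C)=O)C(c2ccc(SC)cc2)C1` keeps the core of compound 1 and its methylsulfanyl group, but carbamoyl becomes acetyl, with methyl in place of amino on a carbonyl carbon.

Among the measured compounds shown here, the only measured single-place step is a 5.3-fold higher number from compound 1 to compound 2 (0.73 log units; beyond the scatter), a modest change that swaps methylsulfanyl for trifluoromethyl on an aromatic carbon. It concerns a different group, so no measurement tests the carbamoyl directly, and it serves only as a rough guide to size. For the measured compounds named here, with compound 1 at 18 nM, the lowest number so far, a modest move toward a higher number in this assay is expected. The estimated change is a 2.8-fold higher number from compound 1 to compound 4 (0.44 log units; beyond the scatter). Compound 4 is expected at 50 nM, with an estimated range from 14 nM to 180 nM.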

Compound 4, half-maximal inhibitory concentration: 42 nM
Beside the measured number, compound 4's estimate is 1.2-fold (0.08 log units) above it; low and high end bracket the measured number.
By their numbers in this assay, from the lowest: compound 1; then compounds 4, 3 and 2 (each within the scatter of the next, the first and the last beyond it).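

In this assay, all three earlier compounds carry carbamoyl, so they gave no reading of this position; replacing it with acetyl, with methyl in place of amino on a carbonyl carbon, gives a 2.3-fold higher number from compound 1 to compound 4 (0.37 log units; beyond the scatter). The step is modest but lies beyond the scatter, so on the methylsulfanyl compound the amino group does bear on the number, yet compound 4 still reads 42 nM without it. No available evidence accounts for this shift.

The compounds shown leave open whether the same swap would have a similar effect with trifluoromethyl in place of methylsulfanyl on the aromatic carbon. They also leave open how a methylamino group, a hydroxyl group or a longer chain such as propanoyl on this carbonyl carbon would compare with amino and methyl.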